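Methylsulfanyl to dimethylamino on a fused core

The source may report more compounds than this note shows. Statements on the series, on what has been measured and on what is new or still open speak of the compounds shown alone.

Within the data shown here, compound 1 `CSc1[nH]ccc2ncnc1-2` and compound 2 `CNc1nccc2c1ncn2C1O[C@H](CO)[C@@H](O)[C@H]1O` are the two measured members of this small set. Only a limit is known for compound 1: in a functional assay on EL4 cells (Mus musculus) for inhibition, tested at 100 uM (on this read-out higher numbers stand for more inhibition at the one concentration tested (going by the name of the read-out) and lower numbers for less inhibition), compound 1 gives < 5%, which is a limit of the assay rather than a number. This is the limit of < 5% in this assay, at which 1 of the 2 values shown sits. Compound 2 gives 11% in this assay. The two values sit within the usual scatter of each other, so no order between compound 1 and compound 2 can be read from them. Compound 3 `CN(C)c1[nH]ccc2ncnc1-2` has not been measured. It differs from compound 1 in one place: dimethylamino in place of methylsulfanyl on an aromatic carbon. Among the measured compounds shown here, no measured step between two compounds is available to show how large a change such a swap brings, so the expected step of a number at least 1 percentage points higher from compound 1 to compound 3 (that floor lies within the scatter) is small and likely within the scatter. Compound 3 is expected to give about 6% in this assay, with a range from 0% to 16%.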

Compound 3, a percentage reported as inhibition, at one concentration (the size of the read-out at that concentration, not a potency): 25%
The estimate for compound 3 lay 19 percentage points below the measured number; measured number outside the range, above it.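

The position on an aromatic carbon next to the ring nitrogen turns out to respond to substitution: in this assay, dimethylamino in place of methylsulfanyl brings a number at least 20 percentage points higher from compound 1 to compound 3 (beyond the scatter). Among these compounds, the earlier pair could show no such thing, since compound 1 and compound 2 stood within the scatter of each other and differ in more than one place, so this is the first single change with a readable direction. The step gives only a lower bound on the size of the change, because the value for compound 1 is a limit and not a number: the limit of < 5% in this assay, at which 1 of the 3 values shown sits.

The compounds shown leave open whether the gain follows from the nitrogen of the dimethylamino group or from this one group alone. Methoxy, with oxygen at the point of attachment, and diethylamino, with longer chains on the nitrogen, would begin to separate these readings.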